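A few compounds are considered here, and "the series" means these few. Any claim that something is new, unique, unknown or untested is made for them only; others in the source may bear on it.

Cytotoxicity notes on the series. In a toxicity assay on NIH3T3 cells (Mus musculus) for cytotoxicity, read by resazurin assay (on this read-out higher numbers stand for an effect only at larger amounts of compound and lower numbers for an effect already at smaller amounts), compound 1 `Nc1cc(-c2ccccc2)ccc1Cn1cncc1CNc1ccc(Cl)c(-c2ccccc2)c1` gives > 1000 nM, which is a limit of the assay and not a number. Compound 3 `CS(=O)(=O)c1ccc(Cn2cncc2CNc2ccc(-c3nc4ccccc4s3)c(-c3ccccc3)c2)cc1` gives in this assay > 1000 nM, again only a limit. Compound 2 `c1ccc(-c2ccc(Cn3cncc3CNc3ccc(-c4ccccc4)c(-c4ccccc4)c3)cc2)cc1` gives in this assay > 10000 nM, likewise a limit and not a number. Compound 2 thus stands at the limit of > 10000 nM in this assay, at which 1 of the 3 values shown sits, the higher of the two limits seen. The other two values sit at the limit of > 1000 nM in this assay, at which 2 of the 3 values shown sit.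

Compound 4 `COc1ccc(NCc2cncn2Cc2ccc(-c3ccccc3)cc2)cc1-c1ccccc1` differs from compound 2 by methoxy in place of phenyl on an aromatic carbon. Among the compounds with values here, no measured step connects two compounds that differ in one place, so the step expected from compound 2 to compound 4, a number no higher from compound 2 to compound 4 (the limit leaves the size open), is none beyond the scatter, with a limit again the likely outcome. Compound 4 is estimated at 10000 nM, within 3000 nM to 30000 nM.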

Compound 4, half-maximal effective concentration: > 1000 nM
Compound 4 gave a limit, no number; the forecaster's own chance of this, stated with the estimate: 80%; the middle value is on the limit's open side.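

Within the data shown here, compound 2 and compound 4 both give only limits in this assay, so no step between them can be read. The compounds shown leave open whether methoxy in place of phenyl on an aromatic carbon changes cytotoxicity at all.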